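The source may report more compounds than this note shows. Statements on the series, on what has been measured and on what is new or still open speak of the compounds shown alone.

Of the compounds shown here, three sharing one core have been measured in an assay on isolated protein for binding affinity to 5-hydroxytryptamine receptor 6 (Homo sapiens); a lower number here means a stronger inhibitor, a higher number a weaker inhibitor. Compound 1 `COc1ccccc1-c1cc(C2CCNC2)ccc1Cl` gives 400 nM. Compound 2 `CNCc1ccc(Cl)c(-c2ccccc2OC)c1` gives 1300 nM, and compound 3 `CCNCc1ccc(Cl)c(-c2ccccc2OC)c1` gives 1400 nM. Of these numbers compound 3 shows the highest, though compound 2 sits within the scatter of it, while the step of a 3.5-fold higher number from compound 1 to compound 3 (0.54 log units; beyond the scatter) lies beyond the scatter. Compound 4 `CCN(CC)Cc1ccc(Cl)c(-c2ccccc2OC)c1` is compound 3 with ethyl in place of hydrogen on an amine nitrogen. Among the compounds with values here, no measured step changes a substituent on the amine nitrogen itself. The closest guide is a 1.1-fold higher number from compound 2 to compound 3 (0.03 log units; within the scatter), where a carbon was added on a saturated chain carbon bound to the amine nitrogen and the number stayed within the scatter. The steps of a 3.3-fold higher number from compound 1 to compound 2 (0.51 log units; beyond the scatter) and a 3.5-fold higher number from compound 1 to compound 3 (0.54 log units; beyond the scatter) show that exchanging the whole amine-bearing group moves the number modestly, so a small further rise cannot be excluded. The step of a 1.4-fold higher number from compound 3 to compound 4 (0.15 log units; within the scatter) is therefore expected. Compound 4 is expected to give 2000 nM, with a range from 700 nM to 6000 nM.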

Compound 4, inhibition constant: 2000 nM
Estimate against measurement, compound 4: no gap at the digits printed; the measured number falls inside the stated range.
By their numbers in this assay, from the lowest: compound 1; then compounds 2, 3 and 4 (each within the scatter of the next).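

In this assay, within the data shown here, this is the first step made on the amine nitrogen itself: with a 1.4-fold higher number from compound 3 to compound 4 (0.15 log units; within the scatter), ethyl in place of hydrogen at this position gives a difference that cannot be told from the scatter. The comparison with the methylamino compound agrees, with a 1.5-fold higher number from compound 2 to compound 4 (0.19 log units; within the scatter), so compounds 2, 3 and 4 cannot be separated by their numbers in this assay. Among these compounds, exchanging the whole amine-bearing group remains the only change here that can be read, since (diethylamino)methyl in place of pyrrolidin-3-yl gives a 5.0-fold higher number from compound 1 to compound 4 (0.70 log units; beyond the scatter), a modest step beyond the scatter. No supporting evidence is available to explain these numbers. Going by these compounds, it remains open whether a longer chain such as propyl, or a benzyl group, on the amine nitrogen would also stay within the scatter.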